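The source may report more compounds than this note shows. Statements on the series, on what has been measured and on what is new or still open speak of the compounds shown alone.

Measured compounds:
- compound 1 `Fc1ccc(-c2csc(N3N=C(c4ccc(N5CCCCC5)cc4)CC3c3ccc(Cl)cc3)n2)cc1`: in a functional assay on A549 cells (Homo sapiens) for antiproliferative activity, read by MTT assay, with a stated time of 72 h (a higher number here means a weaker inhibitor, a lower number a stronger inhibitor), compound 1 gives 70200 nM
- compound 2 `Clc1ccc(C2CC(c3ccc(N4CCCCC4)cc3)=NN2c2nc(-c3ccc(Br)cc3)cs2)cc1`: in this assay compound 2 gives 39700 nM

Compound 2 holds the lower of the two numbers; its nearest neighbour is compound 1, separated by a 1.8-fold lower number from compound 1 to compound 2 (0.25 log units; within the scatter), a halogen exchange that stays within the scatter. Compound 3 `FC(F)(F)c1ccc(-c2csc(N3N=C(c4ccc(N5CCCCC5)cc4)CC3c3ccc(Cl)cc3)n2)cc1` follows from compound 2 by trifluoromethyl in place of bromo on an aromatic carbon. Among the measured compounds shown here, the only step bearing on this position is a 1.8-fold lower number from compound 1 to compound 2 (0.25 log units; within the scatter), which was small; no exchange of a halogen for trifluoromethyl has been measured. The expected step in this assay is therefore none beyond the scatter, a 1.1-fold lower number from compound 2 to compound 3 (0.05 log units; within the scatter). Compound 3 is estimated at 35000 nM, within 12000 nM to 100000 nM.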

Compound 3, half-maximal inhibitory concentration: 42000 nM
For compound 3 the middle estimate is 1.2-fold (0.08 log units) below the measured one; the measured number falls inside the stated range.
By their numbers in this assay, from the lowest: compounds 2, 3 and 1 (each within the scatter of the next).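

In this assay trifluoromethyl in place of bromo gives a 1.1-fold higher number from compound 2 to compound 3 (0.02 log units; within the scatter) and trifluoromethyl in place of fluoro gives a 1.7-fold lower number from compound 1 to compound 3 (0.22 log units; within the scatter) so the larger group of four heavy atoms produces no step beyond the scatter from either halogen. Across these three compounds, this place on the six-membered aromatic ring, para to a large group, shows no separation among the substituents. Nothing measured here bears on the reason for this flat result.

Still open, going by these compounds, is whether an amine, a carboxylic acid or a methoxy group at this place would leave the number unchanged. The compounds shown also leave open whether a change elsewhere on the shared core would move it.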